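Dimethoxyphenyl swap from compound 3 to compound 4

The compounds below may be only part of what the source reports. "The series", "measured", "known", "first", "only" and "open" are said of these compounds alone.

Measured in a functional assay on A549 cells (Homo sapiens) for inhibition, read by MTT assay, with a stated time of 48 h; on this read-out higher numbers stand for weaker inhibition and lower numbers for stronger inhibition:
- compound 1 `Brc1ccc2[nH]cc(C(c3ccccc3)c3c[nH]c4ccc(Br)cc34)c2c1`: 7500 nM
- compound 2 `COc1ccc(C(c2c[nH]c3ccc(Br)cc23)c2c[nH]c3ccc(Br)cc23)cc1`: 10000 nM
- compound 3 `COc1ccc(C(c2c[nH]c3ccc(Br)cc23)c2c[nH]c3ccc(Br)cc23)c(OC)c1`: 100000 nM

In this assay compound 3 has the highest number of the three at 100000 nM, and its steps to both others lie beyond the scatter. Compound 4 `COc1ccc(C(c2c[nH]c3ccc(Br)cc23)c2c[nH]c3ccc(Br)cc23)cc1OC` differs from it by 3,4-dimethoxyphenyl in place of 2,4-dimethoxyphenyl on a saturated chain carbon bound to two aromatic carbons. The two have the same atoms, joined differently.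

Among the measured compounds shown here, three measured steps bear on this change. The first methoxy costs nothing measurable, as seen in a 1.3-fold higher number from compound 1 to compound 2 (0.12 log units; within the scatter), which lies within the scatter. The second methoxy in compound 3 gives a 10-fold higher number from compound 2 to compound 3 (1.00 log units; beyond the scatter), and the two together give a 13-fold higher number from compound 1 to compound 3 (1.12 log units; beyond the scatter). For the measured compounds named here, compound 4 is also compound 2 with one more methoxy, but no measured compound carries the 3,4-dimethoxyphenyl group, so the effect of this swap is uncertain. Given a 10-fold higher number from compound 2 to compound 3 (1.00 log units; beyond the scatter), part of that rise is expected to be lost, with an expected step of a 4.0-fold lower number from compound 3 to compound 4 (0.60 log units; beyond the scatter) in this assay. The estimate for compound 4 is 25000 nM, with an expected range of 8000 nM to 100000 nM.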

Compound 4, half-maximal inhibitory concentration: 12000 nM
For compound 4 the middle estimate is 2.1-fold (0.32 log units) above the measured one, within the range that was stated.
By their numbers in this assay, from the lowest: compounds 1, 2 and 4 (each within the scatter of the next); then compound 3.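

In this assay the swap of 2,4-dimethoxyphenyl for 3,4-dimethoxyphenyl gives an 8.3-fold lower number from compound 3 to compound 4 (0.92 log units; beyond the scatter) and so shows that, among the compounds listed, the large rise in compound 3 goes with that one arrangement of the two methoxy groups and not with a second methoxy as such. With a 1.2-fold higher number from compound 2 to compound 4 (0.08 log units; within the scatter) and a 1.6-fold higher number from compound 1 to compound 4 (0.20 log units; within the scatter) both within the scatter, the saturated chain carbon bound to two aromatic carbons carries 3,4-dimethoxyphenyl with no measurable change, and compound 3 alone goes against this flat picture. Nothing measured here accounts for the gap between the two dimethoxyphenyl groups.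

Still open, going by these compounds, is whether an amine, a carboxylic acid or a longer chain such as ethoxy on this aromatic ring would follow the same pattern as methoxy. Also open, on these data alone, is whether any such group could give a clearly stronger result than compound 1 at 7500 nM in this assay.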